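Trimming the Amino Acid Arm of a Quinone Core

The source may hold more compounds than are shown below. What is called first, only, known or untested is meant among the compounds shown, and "the series" means these compounds.

Compound 1 `CC1=CCC[C@H]2[C@](C)(CC3=CC(=O)C=C(N[C@@H](C(=O)O)C(C)C)C3=O)[C@@H](C)CC[C@]12C` is the strongest inhibitor in a functional assay on HeLa cells (Homo sapiens) for cytotoxicity, read by MTT assay, with a stated time of 72 h (a higher number here means a weaker inhibitor, a lower number a stronger inhibitor), giving 10900 nM. Compound 2 `CSCC[C@H](NC1=CC(=O)C=C(C(C)(C)C)C1=O)C(=O)O` gives 77400 nM and compound 3 `CC(C)C[C@H](NC1=CC(=O)C=C(C(C)(C)C)C1=O)C(=O)O` gives 57200 nM in this assay; both carry a different core from compound 1. Compound 4 `CC1=CCC[C@H]2[C@](C)(CC3=CC(=O)C=C(N[C@@H](C)C(=O)O)C3=O)[C@@H](C)CC[C@]12C` keeps the core of compound 1 but carries 1-carboxyethyl in place of 1-carboxy-2-methylpropyl on an amine nitrogen. For the measured compounds named here, the only measured step that bears on this change is the swap of isopropyl for (methylsulfanyl)methyl on a saturated chain carbon, a 1.4-fold lower number from compound 2 to compound 3 (0.13 log units; within the scatter), which stayed within the scatter. A further change of the amino acid arm is therefore expected to move the number little, if at all. Compound 4 is thus expected to give 15000 nM, within 6000 nM to 40000 nM, a step of a 1.4-fold higher number from compound 1 to compound 4 (0.14 log units; within the scatter).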

Compound 4, half-maximal inhibitory concentration: 11700 nM
The estimate for compound 4 lay 1.3-fold (0.11 log units) above the measured number; the range from low to high includes it.
By their numbers in this assay, from the lowest: compounds 1 and 4 (each within the scatter of the next); then compounds 3 and 2 (each within the scatter of the next).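

On the core of compound 1, 1-carboxyethyl in place of 1-carboxy-2-methylpropyl on an amine nitrogen gives a 1.1-fold higher number from compound 1 to compound 4 (0.03 log units; within the scatter) in this assay. For the compounds shown here, the earlier step changed the arm only on a different core, so this is the first reading of such a change on this core, and the smaller arm leaves the number within the scatter. No measurement shown here explains this result. As far as these compounds go, what an amide in place of the carboxylic acid, or a longer chain bearing an amine, would do to the number on this core stays open.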